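Swapping a Phenyl Side Chain for an Ester Chain

A few compounds are considered here, and "the series" means these few. Any claim that something is new, unique, unknown or untested is made for them only; others in the source may bear on it.

Compound 1 `Cc1nc2cnccc2n1CC1CCN(C(=O)CCc2ccccc2)CC1` gives > 5 mg/kg, which is a limit of the assay rather than a number.
Compound 2 `Cc1nc2cnccc2n1CC1CCN(C(=O)N[C@@H](C)c2ccccc2)CC1` gives 0.21 mg/kg.

Going by the values given here, in a functional assay on the whole organism (arterial blood) with Rattus norvegicus as the target (on this read-out higher numbers stand for an effect only at larger amounts of compound and lower numbers for an effect already at smaller amounts), compound 2 holds the only measured number, the other result being a limit. Compound 1 sits at the limit of > 5 mg/kg in this assay, at which 1 of the 2 values shown sits. Among the compounds with values here, the single measured step is large: an at least 23-fold lower number from compound 1 to compound 2 (1.37 log units; beyond the scatter). Compound 3 `CCOC(=O)[C@H](CC(C)C)NC(=O)N1CCC(Cn2c(C)nc3cnccc32)CC1` is reached from compound 2 by a different kind of change, (1-(ethoxycarbonyl)-3-methylbutyl in place of 1-phenylethyl on an amide-type nitrogen). Within the data shown here, no measured step bears directly on this change, since both measured compounds carry the phenyl ring that compound 3 loses, and the one known step concerns the link to the carbonyl, not the group on the nitrogen. A loss of potency is therefore expected but is uncertain: the step expected is a 5.7-fold higher number from compound 2 to compound 3 (0.76 log units; beyond the scatter). For compound 3 the estimate is 1.2 mg/kg, with a range from 0.25 mg/kg to 6 mg/kg.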

Compound 3, dose for 50% inhibition: 0.03 mg/kg
Compound 3: the middle estimate sits 40-fold (1.60 log units) above what was measured; measured number below the stated range.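

In this assay, the group on the amide-type nitrogen does not need its aromatic ring: putting 1-(ethoxycarbonyl)-3-methylbutyl in place of 1-phenylethyl gives a 7.0-fold lower number from compound 2 to compound 3 (0.85 log units; beyond the scatter). Going by these compounds alone, compound 1 and compound 2 both carry a phenyl ring, so compound 3 is the first sign that a chain with no ring and with an ethyl ester can work at this place, and at a smaller dose than compound 2. Nothing measured among these compounds explains this gain.

A carboxylic acid in place of the ethyl ester, or a plain 3-methylbutyl chain without the ester, would help to show whether the ester itself matters, and the compounds shown leave that open. Going by these compounds, the role of the defined stereocentre in the new chain also remains open, as only one mirror form of it appears here.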